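Hydroxy for 2-aminophenyl on the amide of compound 3

A few compounds are considered here, and "the series" means these few. Any claim that something is new, unique, unknown or untested is made for them only; others in the source may bear on it.

In a functional assay on A549 cells (Homo sapiens) for cytotoxicity, read by resazurin assay (a higher number here means a weaker inhibitor, a lower number a stronger inhibitor), compound 1 (`C#Cc1cccc(Nc2ncnc3ccc(NC(=O)c4ccc(C(=O)Nc5ccccc5N)s4)cc23)c1`) reads > 50000 nM and this is a limit, not a number. Compound 2 (`C#Cc1cccc(Nc2ncnc3cc(NC(=O)c4ccc(C(=O)Nc5ccccc5N)s4)ccc23)c1`) gives 820 nM in this assay and compound 3 (`C#Cc1cccc(Nc2ncnc3ccc(S(=O)(=O)n4ccc(/C=C/C(=O)Nc5ccccc5N)c4)cc23)c1`) gives 3700 nM as the higher of the two numbers, a gap beyond the scatter. Compound 4 (`C#Cc1cccc(Nc2ncnc3ccc(S(=O)(=O)n4ccc(/C=C/C(=O)NO)c4)cc23)c1`) carries hydroxy in place of 2-aminophenyl on an amide-type nitrogen. Going by the values given here, no measured pair shows this exchange, so the size of the step is a judgement only. In this assay the expected step is a 3.7-fold lower number from compound 3 to compound 4 (0.57 log units; beyond the scatter) towards a stronger inhibitor, moderate in size and beyond the scatter. Compound 4 is estimated at 1000 nM with 200 nM to 5000 nM as the expected range.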

Compound 4, half-maximal inhibitory concentration: 240 nM
Estimate against measurement, compound 4: 4.2-fold (0.62 log units) above; low and high end bracket the measured number.
By their numbers in this assay, from the lowest: compound 4; then compound 2; then compound 3. At a limit, above all of these: compound 1.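

In this assay, going by these compounds alone, hydroxy in place of 2-aminophenyl on an amide-type nitrogen gives a 15-fold lower number from compound 3 to compound 4 (1.19 log units; beyond the scatter) and this is the first step that can be read at this position. The aromatic ring of 2-aminophenyl is therefore not needed here for a low number, and the much smaller hydroxy gives the lower value on an otherwise unchanged structure. Nothing available accounts for the size of this step.

On these data alone, whether the same exchange on the amide of compound 2 gives a step of similar size remains open. So does the outcome with other groups on this nitrogen, such as methoxy or 2-hydroxyphenyl, or with a carboxylic acid in place of hydroxycarbamoyl.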